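The compounds below may be only part of what the source reports. "The series", "measured", "known", "first", "only" and "open" are said of these compounds alone.

Of the compounds shown here, three sharing one core have been tested in a functional assay on FM3A cells (Mus musculus) for antiproliferative activity (a lower number here means a stronger inhibitor, a higher number a weaker inhibitor), which reads out a half-maximal inhibitory concentration. Compound 1 `COc1cc(C(=O)c2sc(-c3ccc(-c4ccccc4)cc3)cc2N)cc(OC)c1OC` gives > 10000 nM, and this value is a limit of the assay, not a number. Compound 2 `COc1cc(C(=O)c2sc(-c3ccc(I)cc3)cc2N)cc(OC)c1OC` gives 420 nM, while compound 3 `COc1cc(C(=O)c2sc(-c3ccncc3)cc2N)cc(OC)c1OC` gives 150 nM. Compound 2 therefore holds the higher of the two true numbers, with compound 1 reported only as a limit.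

The next compound to be measured is compound 4 `COc1cc(C(=O)c2sc(-c3ccsc3)cc2N)cc(OC)c1OC`, which has thiophen-3-yl in place of 4-iodophenyl on an aromatic carbon.

Within the data shown here, two measured steps bear on this change. The first, an at least 23-fold lower number from compound 1 to compound 2 (1.37 log units; beyond the scatter), is large, but it replaces phenyl with iodo and leaves the aryl ring attached to the core in place, so it says little here. The closer guide is a 2.8-fold lower number from compound 2 to compound 3 (0.45 log units; beyond the scatter), a modest step that removes the same 4-iodophenyl group. On that evidence from compound 3, a modest move towards a lower number in this assay is expected, though a step that stays within the scatter would be no surprise. The expected change is a 1.9-fold lower number from compound 2 to compound 4 (0.28 log units; within the scatter). For compound 4 the estimated value is 220 nM, with an expected range from 70 nM to 800 nM.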

Compound 4, half-maximal inhibitory concentration: 3.7 nM
Beside the measured number, compound 4's estimate is 59-fold (1.77 log units) above it, outside the stated range (below it).
By their numbers in this assay, from the lowest: compound 4; then compound 3; then compound 2. At a limit, above all of these: compound 1.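

In this assay, among these compounds, the group on this aromatic carbon, next to the ring sulfur, proved far more decisive than the earlier compounds had suggested, with a 110-fold lower number from compound 2 to compound 4 (2.06 log units; beyond the scatter) and, against the other ring without a biphenyl-type extension, a 41-fold lower number from compound 3 to compound 4 (1.61 log units; beyond the scatter) as the two new steps. Both are large, whereas exchanging 4-iodophenyl for pyridin-4-yl had given only a modest change, a 2.8-fold lower number from compound 2 to compound 3 (0.45 log units; beyond the scatter), so the earlier step between two six-membered aromatic rings gave no sign of how low the number could go at this position. Nothing measured among these compounds accounts for the size of this gain.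

Compound 4 is the only compound shown with a five-membered aromatic ring at this position, so the effect of ring size cannot be separated from that of the ring sulfur. On these data alone, it remains open whether unsubstituted phenyl, furan-3-yl with oxygen in the ring, or thiophen-2-yl, which is joined through a different ring carbon, would keep a number close to that of compound 4.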